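The source may report more compounds than this note shows. Statements on the series, on what has been measured and on what is new or still open speak of the compounds shown alone.

In a functional assay on NCI-H1975 cells (Homo sapiens) for inhibition, read by sulforhodamine B assay, tested at 10 uM (on this read-out lower numbers stand for less inhibition and higher numbers for more inhibition at the one concentration tested (going by the name of the read-out)), compound 1 `CN(C)c1ccc(C2CC(c3ccc(-n4ccnc4)cc3)=NN2)cc1` gives 0.1%. Compound 2 `C=C(C)C(=O)N1N=C(c2ccc(-n3ccnc3)cc2)CC1c1ccc(N(C)C)cc1`, which carries a (1-methylethenyl)carbonyl on the ring amine nitrogen, gives -3.7%, the lowest of the two numbers, and the step of a number 3.8 percentage points lower from compound 1 to compound 2 (within the scatter) lies within the scatter. Compound 3 `CN(C)c1ccc(C2CC(c3ccc(-n4ccnc4)cc3)=NN2C(=O)c2ccc(C(F)(F)F)cc2)cc1` differs from compound 2 by 4-(trifluoromethyl)phenyl in place of 1-methylethenyl on a carbonyl carbon, the 4-(trifluoromethyl)phenyl entering on the carbonyl carbon. Going by the values given here, the only measured step at this position is a number 3.8 percentage points lower from compound 1 to compound 2 (within the scatter), within the scatter. The expected step is therefore a number 3.7 percentage points higher from compound 2 to compound 3 (within the scatter), none beyond the scatter. For compound 3 in this assay the estimate is 0%, ranging from -12% to 14%.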

Compound 3, a percentage reported as inhibition, at one concentration (the size of the read-out at that concentration, not a potency): 15.9%
Compound 3: the middle estimate sits 15.9 percentage points below what was measured; the whole stated range lies below it.
By their numbers in this assay, from the lowest: compounds 2 and 1 (each within the scatter of the next); then compound 3.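

In this assay, the substituent on this ring amine nitrogen can change the read-out: 4-(trifluoromethyl)phenyl in place of 1-methylethenyl on the carbonyl carbon gives a number 19.6 percentage points higher from compound 2 to compound 3 (beyond the scatter), and the whole (4-(trifluoromethyl)phenyl)carbonyl in place of hydrogen gives a number 15.8 percentage points higher from compound 1 to compound 3 (beyond the scatter). Going by these compounds alone, the one earlier step here, a number 3.8 percentage points lower from compound 1 to compound 2 (within the scatter), showed no such separation. No supporting data bear on the origin of this gain. 

Still open, as far as these compounds go, is whether the aromatic ring or its trifluoromethyl carries the gain; an unsubstituted phenyl or a 4-methoxyphenyl on the carbonyl carbon would separate the two.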